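The compounds below may be only part of what the source reports. "The series", "measured", "known", "first", "only" and "open" are said of these compounds alone.

Measured compounds in a functional assay on MCF7 cells (Homo sapiens) for inhibition, read by MTT assay, with a stated time of 72 h; on this read-out higher numbers stand for weaker inhibition and lower numbers for stronger inhibition:
- compound 1 `O=C1Nc2ccccc2/C1=N/NC(=S)N1CCN(c2ccccc2)CC1`: 24900 nM
- compound 2 `O=C1Nc2cc(Br)ccc2/C1=N/NC(=S)N1CCN(c2ccccc2)CC1`: 19700 nM
- compound 3 `COc1ccc(N2CCN(C(=S)N/N=C3\C(=O)Nc4ccc(Cl)cc43)CC2)cc1`: 13800 nM

Compound 3 gives the lowest of the three numbers in this assay, but its gap to compound 2 and to compound 1 is within the scatter, so the three stand level. Compound 4 `O=C1Nc2ccc(Cl)cc2/C1=N/NC(=S)N1CCN(c2ccccc2Cl)CC1` differs from compound 3 by 2-chlorophenyl in place of 4-methoxyphenyl on an amine nitrogen in a ring. Within the data shown here, the only measured step, a 1.3-fold lower number from compound 1 to compound 2 (0.10 log units; within the scatter), concerns a substituent on the aromatic carbon of the core, not the aryl on the ring nitrogen, and it itself stayed within the scatter. Among the measured compounds shown here, no measured pair informs on the aryl exchange, so no step beyond the scatter is expected in this assay. For compound 4 the estimate is 14000 nM, range 6000 nM to 35000 nM, a step of a 1.0-fold higher number from compound 3 to compound 4 (0.01 log units; within the scatter) expected.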

Compound 4, half-maximal inhibitory concentration: 11700 nM
Compound 4: middle estimate off by 1.2-fold (0.08 log units), on the high side; low and high end bracket the measured number.
By their numbers in this assay, from the lowest: compounds 4, 3, 2 and 1 (each within the scatter of the next, the first and the last beyond it).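

In this assay, 2-chlorophenyl in place of 4-methoxyphenyl on the amine nitrogen in the ring gives a 1.2-fold lower number from compound 3 to compound 4 (0.07 log units; within the scatter), the only pair shown that bears on the aryl group at this position. The exchange removes the hydrogen-bond acceptor counted on the leaving group and brings in a chlorine, yet the step stays within the scatter. No available evidence explains this result.

Only these two substituted phenyl groups can be compared at this nitrogen on the shared core. On these data alone, a methyl in place of the aryl group, or a carboxylic acid or an amine on the phenyl ring, remains open in this assay.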